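The source may report more compounds than this note shows. Statements on the series, on what has been measured and on what is new or still open speak of the compounds shown alone.

Of the compounds shown here, two built on a shared core have been measured in a physicochemical assay for lipophilicity; a lower number here means a more polar compound, a higher number a more lipophilic compound. Compound 1 `Ic1ccccc1C1=NC(c2ccccc2)CO1` gives 3.86 in this assay. Compound 2 `Cc1ccc(C2=NC(c3ccccc3)CO2)cc1` gives 4.11 in this assay, and the two numbers lie within the scatter of each other, so compound 1 stands alongside compound 2 rather than apart from it. For the measured compounds named here, no pair among the measured compounds differs in one place alone, so no single measured step is available for comparison.

Compound 3 `Clc1ccccc1C1=NC(c2ccccc2)CO1` has not yet been measured in this assay. The change from compound 1 to compound 3 is chloro in place of iodo on an aromatic carbon. Going by the values given here, no measured step of this kind is at hand. Starting from compound 1 at 3.86, a moderate decrease is expected in this assay, somewhat beyond the scatter, a step of a number 0.41 log units lower from compound 1 to compound 3 (beyond the scatter). Compound 3 is therefore estimated at 3.45 in this assay, with a range from 3.1 to 3.8.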

Compound 3, partition coefficient: 3.56
The estimate for compound 3 lay 0.11 log units below the measured number; the range from low to high includes it.
By their numbers in this assay, from the lowest: compounds 3, 1 and 2 (each within the scatter of the next, the first and the last beyond it).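

Chloro in place of iodo on an aromatic carbon, ortho to a large group, gives the first comparison in this set that differs in one place alone. In this assay, the step of a number 0.30 log units lower from compound 1 to compound 3 (within the scatter) does not separate the two halogens at this position, so the exchange of iodo for chloro has no effect here that can be told from repeat measurement. Nothing available bears on what lies behind this result.

The compounds shown leave open whether an amine, a carboxylic acid or a longer chain on this same aromatic carbon would stand apart from chloro and iodo in this assay. They also leave open whether the same exchange of chloro for iodo would read alike on another aromatic carbon of this ring.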